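A triazole acetamide series: swapping the anilide aryl group

A few compounds are considered here, and "the series" means these few. Any claim that something is new, unique, unknown or untested is made for them only; others in the source may bear on it.

Of the compounds shown here, three built on the same core have been measured in a functional assay on HeLa cells (Homo sapiens) for inhibition, read by MTT assay, with a stated time of 24 h; a higher number here means a weaker inhibitor, a lower number a stronger inhibitor. Compound 1 `CCOC(=O)C1=Cc2ccccc2OC1(OCc1cc(-c2ccc(F)cc2F)no1)C(F)(F)F` reaches only the limit of the assay, (the limit of > 150000 nM in this assay, at which 1 of the 3 values shown sits), so for compound 1 the value > 150000 nM is a limit and not a number. Going by the values given here, compound 3 `CCOC(=O)C1=Cc2ccccc2OC1(OCc1cc(-c2cccc(C(F)(F)F)c2)no1)C(F)(F)F` gives 21400 nM, and the change an at least 7.0-fold lower number from compound 1 to compound 3 (0.84 log units; beyond the scatter) is the only measured step in which one structural change alone is compared. Compound 2 `CCOC(=O)C1=Cc2ccccc2OC1(OCc1cn(CC(=O)Nc2ccc(C)cc2)nn1)C(F)(F)F` gives 67400 nM, which is the higher of the two numbers actually measured; it sits beyond the scatter above compound 3.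

Compound 4 `CCOC(=O)C1=Cc2ccccc2OC1(OCc1cn(CC(=O)Nc2cccc(F)c2)nn1)C(F)(F)F` has not yet been measured in this assay. It differs from compound 2 only by 3-fluorophenyl in place of 4-methylphenyl on an amide-type nitrogen. Among the compounds with values here, no measured step touches this part of the structure, so the measured change from compound 1 to compound 3 cannot be carried over directly. The expected step from compound 2 to compound 4 is therefore small, a 1.3-fold lower number from compound 2 to compound 4 (0.13 log units; within the scatter), with no clear direction. Compound 4 is expected to give about 50000 nM, within a range from 20000 nM to 150000 nM.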

Compound 4, half-maximal inhibitory concentration: > 150000 nM
Compound 4: no number, only a limit; the forecaster's own chance of this, stated with the estimate: 15%; at least 3.0-fold (0.47 log units) between middle value and limit.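

In this assay, 3-fluorophenyl in place of 4-methylphenyl on the amide-type nitrogen gives an at least 2.2-fold higher number from compound 2 to compound 4 (0.34 log units; beyond the scatter). This part of the structure, which the earlier step did not touch, therefore matters to the result: the change leads to a weaker inhibitor, even though both groups have the same number of heavy atoms and the same kind of ring. Compound 4 gives a limit and not a number, so the full size of the step stays unknown: the limit of > 150000 nM in this assay, at which 2 of the 4 values shown sit.

The compounds shown cannot separate losing the 4-methyl group from gaining the 3-fluoro group, which a plain phenyl or a 4-fluorophenyl on the same nitrogen could help to do. Also open, from the compounds shown here alone, is how an amine or a carboxylic acid on this ring would read.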